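The source may hold more compounds than are shown below. What is called first, only, known or untested is meant among the compounds shown, and "the series" means these compounds.

Compound 3 (`O=C(COCc1ccncn1)N1CCN(c2ccc(Cl)cc2Cl)CC1`) gives 2800 nM in a functional assay on HEK293 cells for positive allosteric modulation of metabotropic glutamate receptor 5 (Homo sapiens), read by FLIPR and calcium flux (a lower number here means that less compound is needed, a higher number that more compound is needed for the effect), the highest number among the three measured compounds. Within the data shown here, its nearest neighbour is compound 2 (`O=C(COCc1cccnc1)N1CCN(c2ccc(Cl)cc2Cl)CC1`), which gives 1090 nM in this assay; the only one-step comparison available is a 2.6-fold higher number from compound 2 to compound 3 (0.41 log units; beyond the scatter). Compound 1 (`O=C(COCc1ccncc1)N1CCN(c2ccc(Cl)cc2F)CC1`) gives 600 nM in this assay, but it differs from compound 2 in two places at once, so the two values can only be set side by side without reading a single change from them.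

Compound 4 (`N#Cc1ccc(COCC(=O)N2CCN(c3ccc(Cl)cc3Cl)CC2)s1`) has not been measured. Its difference from compound 3 is 5-cyanothiophen-2-yl in place of pyrimidin-4-yl on a saturated chain carbon bound to an oxygen on a saturated carbon. Among the measured compounds shown here, the one measured step that bears on this position, a 2.6-fold higher number from compound 2 to compound 3 (0.41 log units; beyond the scatter), shows that exchanging one six-membered aromatic ring for another at the carbon bound to the ether oxygen moved the number by a modest amount beyond the scatter. The new ring in compound 4 is of a kind not represented among the measured compounds, so the direction rests on that single step alone and is uncertain. Compound 4 is therefore expected to give a somewhat lower number than compound 3, with the step estimated as a 2.2-fold lower number from compound 3 to compound 4 (0.33 log units; beyond the scatter), and an estimate for compound 4 of 1300 nM with a range from 400 nM to 4500 nM.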

Compound 4, half-maximal effective concentration: 210 nM
Estimate against measurement, compound 4: 6.2-fold (0.79 log units) above; measured number outside the range, below it.
By their numbers in this assay, from the lowest: compound 4; then compounds 1 and 2 (each within the scatter of the next); then compound 3.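

Among these compounds, at the saturated chain carbon bound to an oxygen on a saturated carbon, the earlier compounds showed only an exchange of one six-membered aromatic ring for another, which gave a 2.6-fold higher number from compound 2 to compound 3 (0.41 log units; beyond the scatter) in this assay. The five-membered 5-cyanothiophen-2-yl ring moves the number much further and the other way, with a 13-fold lower number from compound 3 to compound 4 (1.12 log units; beyond the scatter) against pyrimidin-4-yl and a 5.2-fold lower number from compound 2 to compound 4 (0.72 log units; beyond the scatter) against pyridin-3-yl, so this position responds far more strongly to the choice of ring than the first step suggested, and the new group gives a lower number than both rings it can be compared with here. Nothing available accounts for the size of this change.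

The exchange alters the ring size, brings in sulfur and adds the nitrile all at once, so these compounds cannot show which of these changes goes with the lower number; a plain thiophen-2-yl or a 4-cyanophenyl group at this place would separate them. From the compounds shown here alone, it also stays open whether 5-cyanothiophen-2-yl would lower the number to the same degree on the core of compound 1.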